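The source may hold more compounds than are shown below. What is called first, only, known or untested is meant among the compounds shown, and "the series" means these compounds.

Measured compounds in a functional assay on A549 cells (Homo sapiens) for cytotoxicity, read by MTT assay, with a stated time of 24 h; on this read-out lower numbers stand for stronger inhibition and higher numbers for weaker inhibition:

- compound 1 `Cc1ccc(C(=O)NN=C2CC(c3ccccc3)NC(c3ccccc3)C2)cc1`: > 400000 nM, a limit of the assay, not a number
- compound 2 `O=C(NN=C1CC(c2ccccc2)NC(c2ccccc2)C1)c1ccc([N+](=O)[O-])cc1`: > 400000 nM, likewise a limit of the assay, not a number

Compound 2 therefore stands at the limit of this assay, with no number for it. For the measured compounds named here, the single step recorded in this assay, a step that the two limits leave unreadable from compound 1 to compound 2, is of unreadable size, since both of its values sit at the limit; this is what the limit of > 400000 nM in this assay, at which 2 of the 2 values shown sit, states.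

Compound 3 `O=C(NN=C1CC(c2ccccc2)NC(c2ccccc2)C1)c1ccc([N+](=O)[O-])cc1[N+](=O)[O-]` differs from compound 2 by nitro in place of hydrogen on an aromatic carbon of a six-membered aromatic ring of carbon only, ortho to a large group and meta to a nitro group. Going by the values given here, the only measured step that bears on this change is the one from compound 1 to compound 2, and its size cannot be read. Among the compounds with values here, no direction and no size of step can thus be drawn from the measured pairs.

Because the limit of > 400000 nM in this assay, at which 2 of the 2 values shown sit, shows both measured compounds at the limit, compound 3 is expected to stay there as well, with an expected step that the limit leaves unreadable from compound 2 to compound 3. Compound 3 is estimated at 500000 nM, with an expected range from 150000 nM to 3000000 nM.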

Compound 3, half-maximal inhibitory concentration: > 400000 nM
Compound 3: only a limit was reported; the forecaster's own chance of this, stated with the estimate: 85%; the middle value lies beyond the limit too.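

In this assay compound 3 gives > 400000 nM, a limit of the assay and not a number. No step can be read between compound 2 and compound 3, as both sit at a limit: the limit of > 400000 nM in this assay, at which 3 of the 3 values shown sit.

Left open is how compound 1, compound 2 and compound 3 rank against one another in this assay, and whether any change to the shared core would give a number there.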